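A few compounds are considered here, and "the series" means these few. Any claim that something is new, unique, unknown or untested is made for them only; others in the source may bear on it.

Measured so far:
compound 1 `Cc1ccc(C(=O)N2CCN(c3nc(=O)c4cc(C(F)(F)F)cc([N+](=O)[O-])c4s3)CC2)cc1` — 6.7 ug/mL
compound 2 `O=C(c1cccc(F)c1)N1CCN(c2nc(=O)c3cc(C(F)(F)F)cc([N+](=O)[O-])c3s2)CC1` — 0.2 ug/mL

In a physicochemical assay for solubility, read by HPLC (on this read-out lower numbers stand for lower solubility and higher numbers for higher solubility), compound 2 stands lowest of the two numbers, the nearest being compound 1. Compound 3 `CC(C)CC(=O)N1CCN(c2nc(=O)c3cc(C(F)(F)F)cc([N+](=O)[O-])c3s2)CC1` differs from compound 2 by isobutyl in place of 3-fluorophenyl on a carbonyl carbon. Within the data shown here, the only measured step at the carbonyl carbon is a 34-fold lower number from compound 1 to compound 2 (1.53 log units; beyond the scatter), which swaps one six-membered aromatic ring for another, so it bears on this step only loosely; no aryl-to-alkyl step has been measured. The direction is therefore open, and a step of middling size in either direction would not surprise. Compound 3 is expected at 2 ug/mL (range 0.3 ug/mL to 15 ug/mL), an estimated step of a 10-fold higher number from compound 2 to compound 3 (1.00 log units; beyond the scatter).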

Compound 3, solubility: 66.3 ug/mL
Estimate against measurement, compound 3: 33-fold (1.52 log units) below; measured number outside the range, above it.
By their numbers in this assay, from the lowest: compound 2; then compound 1; then compound 3.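

In this assay the carbonyl carbon carries an open-chain group with a large rise over 3-fluorophenyl (a 330-fold higher number from compound 2 to compound 3 (2.52 log units; beyond the scatter)) and a modest rise over 4-methylphenyl (a 9.9-fold higher number from compound 1 to compound 3 (1.00 log units; beyond the scatter)). Both aryl compounds therefore sit below the isobutyl compound, and the range at this position spans more than the aryl pair alone showed. Nothing on hand accounts for the difference. Still open, going by these compounds, is whether a longer chain, a cyclohexyl ring or an aminomethyl group on the same carbonyl carbon keeps this number. Also open, on these data alone, is whether the loss of the aromatic ring or the isobutyl chain itself sets it.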